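The source may hold more compounds than are shown below. What is called first, only, known or untested is meant among the compounds shown, and "the series" means these compounds.

Of the compounds shown here, three built on one shared core have been tested in an ADME assay on MT4 cells (Homo sapiens) for cytotoxicity, read by MTT assay, with a stated time of 96 h; on this read-out higher numbers stand for lower toxicity in this test and lower numbers for higher toxicity in this test. There, compound 1 `NS(=O)(=O)c1ccc(N2N=C(c3ccccc3)CC2c2ccccc2F)cc1` gives 42000 nM, and compound 3 `Cc1ccc(C2CC(c3ccc(Oc4ccccc4)cc3)=NN2c2ccc(S(N)(=O)=O)cc2)cc1` gives 7200 nM. Compound 2 `NS(=O)(=O)c1ccc(N2N=C(c3ccc(OCc4ccccc4)cc3)CC2c2ccc(F)cc2)cc1` gives only a limit of the assay, > 100000 nM, and no number. Compound 4 `Cc1cccc(C2CC(c3ccc(OCc4ccccc4)cc3)=NN2c2ccc(S(N)(=O)=O)cc2)c1` has 3-methylphenyl in place of 4-fluorophenyl on a saturated ring carbon. For the measured compounds named here, no measured pair isolates this change, so the expectation rests on the values alone. A move towards higher toxicity is expected, since compound 3, which also bears a methylphenyl group on that carbon, gives 7200 nM. The expected step, of uncertain size, is an at least 3.3-fold lower number from compound 2 to compound 4 (0.52 log units; beyond the scatter). The estimated value for compound 4 is 30000 nM, within a range from 8000 nM to 100000 nM.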

Compound 4, half-maximal cytotoxic concentration: 44000 nM
Estimate against measurement, compound 4: 1.5-fold (0.17 log units) below; the measured number falls inside the stated range.
By their numbers in this assay, from the lowest: compound 3; then compounds 1 and 4 (each within the scatter of the next). At a limit, above all of these: compound 2.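

In this assay, for the compounds shown here, placing 3-methylphenyl in place of 4-fluorophenyl on a saturated ring carbon gives an at least 2.2-fold lower number from compound 2 to compound 4 (0.35 log units; beyond the scatter), the first sign that the group at this position registers in this read-out. That step is only a minimum because compound 2 gives a limit and not a number: the limit of > 100000 nM in this assay, at which 1 of the 4 values shown sits.

The compounds shown do not separate the loss of the fluorine from the gain of the methyl group. Also open, going by these compounds, is how an aminophenyl or carboxyphenyl group at this carbon would read with the rest of compound 4 unchanged.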